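This account rests on a few compounds, and the source may have more. Where it says the series, first, only, none or still open, it means among the compounds named here.

Compound 1 `CC(=O)c1ccc(N2CCN(C(=O)c3oc(C)nc3-c3ccccc3)CC2)cc1` belongs to a small set of amides built on a shared core, and in a functional assay on HL-60 cells (Homo sapiens) for inhibition, read by MTT assay, with a stated time of 72 h (a lower number here means a stronger inhibitor, a higher number a weaker inhibitor), compound 1 gives "not active" (no number reported), that is, no single number is recorded for it. Compound 2 `CCCc1nc(-c2ccc(OC)cc2)c(C(=O)N2CCN(c3cccc(Cl)c3)CC2)o1` shares that core and in this assay compound 2 likewise gives "not active" (no number reported), again without a number. Going by the values given here, the only compound of the set with a measured concentration is compound 3 `CCC[C@H](Nc1nc(-c2ccc(NC(=O)NCC)c(OC)c2)ncc1C)c1cccnc1`, built on a different core, and in this assay compound 3 gives 112 nM. Where compound 1 stands can therefore be said only in words: it is one of two entries without a number, and it cannot be placed against compound 3 by any counted step.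

Compound 4 `Cc1nc(-c2ccccc2)c(C(=O)N2CCN(c3ccc(C)c(C)c3)CC2)o1` is the compound to be measured. It differs from compound 1 in one place (3,4-dimethylphenyl in place of 4-acetylphenyl on an amine nitrogen in a ring). Among the compounds with values here, since compound 1 has no number, no step between the two can be sized in this assay, and none beyond the scatter is expected in either direction; the expectation is rather that compound 4 will also end without a number, as compound 1 and compound 2 did. Should a value nonetheless be reported, compound 4 is expected to give about 30000 nM, within a range from 5000 nM to 150000 nM.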

Compound 4, half-maximal inhibitory concentration: 43 nM
For compound 4 the middle estimate is 700-fold (2.84 log units) above the measured one, outside the stated range (below it).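

In this assay, going by these compounds alone, compound 4 gives 43 nM while compound 1 gives "not active" (no number reported) and so no step between these two compounds can be read. The compounds shown leave open how other groups at this place on the shared core would read out in this assay. Nothing measured here explains the result of compound 4.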